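Compound 1 and a Longer Piperazine Substituent on a Shorter Chain

The source may report more compounds than this note shows. Statements on the series, on what has been measured and on what is new or still open speak of the compounds shown alone.

Compound 1 `CN1CCN(CCCCCn2c3c(c4ccccc42)C(=O)c2c[n+]([O-])c4ccccc4c2C3=O)CC1` is measured in a functional assay on MCF7 cells (Homo sapiens) for cytotoxicity, read by MTT assay, with a stated time of 72 h (on this read-out higher numbers stand for weaker inhibition and lower numbers for stronger inhibition), where compound 1 gives 1260 nM, the highest of the two numbers recorded. Compound 2 `CC1(C)OCC(Cn2cc(Cn3c4c(c5ccccc53)C(=O)c3c[n+]([O-])c5ccccc5c3C4=O)nn2)O1` gives 290 nM in this assay. Compound 3 `CC1(C)OC[C@@H](Cn2cc(Cn3c4c(c5ccccc53)C(=O)c3c[n+]([O-])c5ccccc5c3C4=O)nn2)O1` reaches only > 1000 nM in this assay, which is a limit and not a number. For the measured compounds named here, the single measured step, an at least 3.4-fold higher number from compound 2 to compound 3 (0.53 log units; beyond the scatter), concerns a stereocentre drawn with a configuration in one compound and without one in the other, and says nothing about the change now considered. Compound 4 `CCCN1CCN(CCCCn2c3c(c4ccccc42)C(=O)c2c[n+]([O-])c4ccccc4c2C3=O)CC1` differs from compound 1 by 4-propylpiperazin-1-yl in place of (4-methylpiperazin-1-yl)methyl on a saturated chain carbon, four bonds along the chain from an aromatic nitrogen. Going by the values given here, with no measured step bearing on this change, a step within the scatter is expected: a 1.1-fold lower number from compound 1 to compound 4 (0.06 log units; within the scatter). Compound 4 is therefore estimated to give 1100 nM, between 400 nM and 3500 nM.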

Compound 4, half-maximal inhibitory concentration: 1280 nM
Estimate against measurement, compound 4: 1.2-fold (0.07 log units) below; measured number inside the range.
By their numbers in this assay, from the lowest: compound 2; then compounds 1 and 4 (each within the scatter of the next).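

In this assay, placing 4-propylpiperazin-1-yl instead of (4-methylpiperazin-1-yl)methyl on this saturated chain carbon gives a 1.0-fold higher number from compound 1 to compound 4 (0.01 log units; within the scatter) as the result. For the compounds shown here, this is the first measured step at this position, and it shows that this exchange of one piperazine group for the other does not separate the two compounds. Nothing measured here explains this match.

Still open, going by these compounds, is whether a morpholine in place of the piperazine would separate from these two compounds. The same question applies to a carboxylic acid at the end of the chain.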